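Shifting the amine along the side chain of compound 2

The source may report more compounds than this note shows. Statements on the series, on what has been measured and on what is new or still open speak of the compounds shown alone.

Compound 1 `N[C@@H](CC1CCCCC1)CN(C(=O)[C@@H]1C[C@H]1c1ccccc1)c1ccc(-c2ccccc2)cc1`: 1.7 nM
Compound 2 `CCC(CC)C(N)CCN(C(=O)[C@@H]1C[C@H]1c1ccccc1)c1ccc(-c2ccccc2)cc1`: 2 nM

Compound 1 and compound 2 were both tested in a functional assay for agonist activity at G protein-coupled receptor 88 (Homo sapiens), read by HTRF and cAMP accumulation; a lower number here means that less compound is needed, a higher number that more compound is needed for the effect. Compound 2 holds the higher of the two numbers, though the step of a 1.2-fold higher number from compound 1 to compound 2 (0.07 log units; within the scatter) lies within the scatter, so the two compounds are not distinguished. Compound 3 `CC(C)CCNCCN(C(=O)[C@@H]1C[C@H]1c1ccccc1)c1ccc(-c2ccccc2)cc1` differs from compound 2 by isopentylamino in place of 1-amino-2-ethylbutyl on a saturated chain carbon, two bonds along the chain from an amide-type nitrogen. For the measured compounds named here, the one measured step only varied the branching beside the amine and left the number unchanged; it does not speak to moving the nitrogen itself. Compound 3 is therefore estimated to give 6 nM (range 1.5 nM to 30 nM), a step of a 3.0-fold higher number from compound 2 to compound 3 (0.48 log units; beyond the scatter) that is expected but uncertain.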

Compound 3, half-maximal effective concentration: 5.1 nM
Compound 3: middle estimate off by 1.2-fold (0.07 log units), on the high side; low and high end bracket the measured number.
By their numbers in this assay, from the lowest: compounds 1 and 2 (each within the scatter of the next); then compound 3.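

Placing the nitrogen inside the chain, as isopentylamino in place of 1-amino-2-ethylbutyl, is the first change at this position to move the number in this assay: there is a 2.6-fold higher number from compound 2 to compound 3 (0.41 log units; beyond the scatter) and also a 3.0-fold higher number from compound 1 to compound 3 (0.48 log units; beyond the scatter) in the comparison with the 1-amino-2-cyclohexylethyl side chain. Both steps are modest, so compound 3 stays in the low nanomolar range at 5.1 nM even with this change. Nothing at hand explains the shift.

Still open, going by these compounds, is whether a hydroxyl group in place of the amine would keep the effect, and whether a longer chain carrying the isopentylamino group would recover or widen the gap.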